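A few compounds are considered here, and "the series" means these few. Any claim that something is new, unique, unknown or untested is made for them only; others in the source may bear on it.

Going by the values given here, in a functional assay on EOL1 cells (Homo sapiens) for antiproliferative activity (on this read-out lower numbers stand for stronger inhibition and higher numbers for weaker inhibition), compound 1 `C/C=C/Cn1cc(-c2ccc(C(=O)NC3CCS(=O)(=O)CC3)c(Cl)c2)n2cncc2c1=O` gives 5340 nM as the higher of the two numbers measured so far. Among the compounds with values here, compound 2 `C/C=C/Cn1cc(-c2ccc(C(=O)N3CCN(S(C)(=O)=O)CC3)c(Cl)c2)n2cncc2c1=O` gives 2290 nM in this assay and the single measured step of a 2.3-fold lower number from compound 1 to compound 2 (0.37 log units; beyond the scatter) is modest but beyond the scatter. Compound 3 `C/C=C/Cn1cc(-c2ccc(C(=O)N3CCOCC3)c(Cl)c2)n2cncc2c1=O` has not yet been measured. It carries morpholin-4-yl in place of (1,1-dioxothian-4-yl)amino on a carbonyl carbon, and the counted change (morpholin-4-yl in place of (1,1-dioxothian-4-yl)amino on a carbonyl carbon) leaves the core of compound 1 untouched. Only compound 2 bears on this change, losing the same group for 4-(methylsulfonyl)piperazin-1-yl and reading 2290 nM in that step. On this one precedent a modest move to a lower number is expected in this assay and the estimated step of a 2.1-fold lower number from compound 1 to compound 3 (0.31 log units; beyond the scatter) is of that size. The estimated value for compound 3 is 2600 nM with 900 nM to 6500 nM as the expected range.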

Compound 3, half-maximal inhibitory concentration: 8170 nM
The estimate for compound 3 lay 3.1-fold (0.50 log units) below the measured number; measured number outside the range, above it.
By their numbers in this assay, from the lowest: compound 2; then compounds 1 and 3 (each within the scatter of the next).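

At the carbonyl carbon, morpholin-4-yl in place of (1,1-dioxothian-4-yl)amino gives a 1.5-fold higher number from compound 1 to compound 3 (0.18 log units; within the scatter) in this assay, so removing the hydrogen-bond donor and the sulfur-bearing ring does not separate these two compounds. The lower number seen with 4-(methylsulfonyl)piperazin-1-yl therefore does not carry over to every ring amide at this place: replacing that group with morpholin-4-yl gives a 3.6-fold higher number from compound 2 to compound 3 (0.55 log units; beyond the scatter), and compound 2 alone stands apart among the three. Nothing available explains this difference.

The compounds shown leave open whether the methylsulfonyl group or the piperazine ring accounts for the number of compound 2. A piperazine bearing an acetyl group, or a free amine at that nitrogen, would separate these two parts.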